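From 4-fluorobenzyl to 4-methylbenzyl: compound 3 to compound 4

The compounds below may be only part of what the source reports. "The series", "measured", "known", "first", "only" and "open" are said of these compounds alone.

In an ADME assay on MT4 cells (Homo sapiens) for cytotoxicity, read by XTT assay, with a stated time of 3 days (on this read-out higher numbers stand for lower toxicity in this test and lower numbers for higher toxicity in this test), compound 1 (`COc1ccc(Cc2cc(OC3CCCCC3C)c(C(C)C)c(=O)[nH]2)cc1`) gives 74500 nM and compound 2 (`CC(C)c1c(OC2CCCCC2C)cc(Cc2ccc(Cl)cc2)[nH]c1=O`) gives 84000 nM while compound 3 (`CC(C)c1c(OC2CCCCC2C)cc(Cc2ccc(F)cc2)[nH]c1=O`) gives 64600 nM and so sits within the scatter of both. The change to compound 4 (`Cc1ccc(Cc2cc(OC3CCCCC3C)c(C(C)C)c(=O)[nH]2)cc1`) is methyl in place of fluoro on an aromatic carbon, para to a large group. Exchanges on this aromatic carbon give a 1.1-fold higher number from compound 1 to compound 2 (0.05 log units; within the scatter) and a 1.2-fold lower number from compound 1 to compound 3 (0.06 log units; within the scatter) and a 1.3-fold lower number from compound 2 to compound 3 (0.11 log units; within the scatter) so no step beyond the scatter is expected in this assay here. The expected step is a 1.1-fold higher number from compound 3 to compound 4 (0.05 log units; within the scatter) with no firm direction. The estimate for compound 4 is 72000 nM (expected range 45000 nM to 115000 nM).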

Compound 4, half-maximal cytotoxic concentration: 112000 nM
Compound 4: middle estimate off by 1.6-fold (0.19 log units), on the low side; the range from low to high includes it.
By their numbers in this assay, from the lowest: compounds 3, 1, 2 and 4 (each within the scatter of the next).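

Methyl joins methoxy, chloro and fluoro on this aromatic carbon, para to a large group, and in this assay its steps are a 1.7-fold higher number from compound 3 to compound 4 (0.24 log units; within the scatter) and a 1.3-fold higher number from compound 2 to compound 4 (0.12 log units; within the scatter) and a 1.5-fold higher number from compound 1 to compound 4 (0.18 log units; within the scatter). Within the data shown here, all four groups therefore remain within the scatter of one another at this position, so the new group separates no compound from the others. No measurement here bears on the reason for these numbers.

On these data alone, whether an amine, a carboxylic acid or a longer chain on this carbon would give a step beyond the scatter remains open. The shown compounds also leave open how changes to the isopropyl or 2-methylcyclohexyloxy groups would read out.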